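The compounds below may be only part of what the source reports. "The series", "measured", "known", "first", "only" and "open" are said of these compounds alone.

Working notes on the series.

Among the compounds with values here, compound 1 `COc1cc2c(cc1OC)C(CC(=O)N(C)C)CC2` stands as the higher of the two numbers so far in a functional assay on the whole organism (strain Wistar) for inhibition, with Rattus norvegicus as the target, read by paw edema, with stated times of 60 min and 6 h, at a dose of 100 mg/kg by the oral route (on this read-out lower numbers stand for less inhibition and higher numbers for more inhibition at the one dose given (going by the name of the read-out)), where compound 1 gives 33.3%. Compound 2 `CCNC(=O)CC1CCc2cc(OC)c(OC)cc21` gives 20.4% in this assay; the change of ethylamino in place of dimethylamino on a carbonyl carbon produces a number 12.9 percentage points lower from compound 1 to compound 2 (beyond the scatter), a modest step beyond the scatter.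

Compound 3 `COc1cc2c(cc1OC)C(CC(=O)N1CCCCC1)CC2` differs from compound 1 in one place: piperidin-1-yl in place of dimethylamino on a carbonyl carbon. Within the data shown here, no measured step covers a ring-closed amine on this carbonyl carbon; the one step at hand, from compound 1 to compound 2, concerns a different replacement and so bears only indirectly on it. Absent a closer precedent, the step from compound 1 to compound 3 is expected to be small, a number 3.3 percentage points lower from compound 1 to compound 3 (within the scatter), with neither direction favoured beyond the scatter. Compound 3 is therefore estimated at 30% in this assay, between 15% and 45%.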

Compound 3, a percentage reported as inhibition, in the whole organism at one dose (the size of the read-out at that dose, not a potency): 31.5%
For compound 3 the middle estimate is 1.5 percentage points below the measured one; low and high end bracket the measured number.
By their numbers in this assay, from the lowest: compound 2; then compounds 3 and 1 (each within the scatter of the next).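

In this assay the carbonyl carbon takes piperidin-1-yl in place of dimethylamino with a number 1.8 percentage points lower from compound 1 to compound 3 (within the scatter) and so closing the amine into a six-membered non-aromatic ring, with more heavy atoms, leaves the read-out level at this dose. Piperidin-1-yl in place of ethylamino gives a number 11.1 percentage points higher from compound 2 to compound 3 (beyond the scatter) and so, among these three compounds, ethylamino alone stands apart at this position, while compound 1 and compound 3 read alike. Nothing at hand explains why these groups read as they do.

On these data alone, whether pyrrolidin-1-yl, with a smaller ring, or morpholin-4-yl, with oxygen as a second ring hetero atom, would stay level with compound 1 remains open. Also open, as far as these compounds go, is what a carboxylic acid or an unsubstituted amino group would give on the same carbonyl carbon.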